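Replacing a hydroxypyrrolidine sulfonyl group with cyclopropyl

The source may report more compounds than this note shows. Statements on the series, on what has been measured and on what is new or still open speak of the compounds shown alone.

Of the compounds shown here, two have been measured so far in a functional assay on MIA PaCa-2 cells (Homo sapiens) for inhibition, read by MTT assay, with a stated time of 7 days; on this read-out lower numbers stand for stronger inhibition and higher numbers for weaker inhibition. Compound 1 `CCN(CC)C(=O)c1ccc(S(=O)(=O)N2CCC[C@@H](C(=O)N3CCC(F)(F)CC3)C2)cc1` gives 70 nM, and compound 2 `O=C([C@@H]1CCCN(S(=O)(=O)c2ccc(S(=O)(=O)N3CC[C@H](O)C3)cc2)C1)N1CCC(F)(F)CC1` gives 590 nM. For the measured compounds named here, the single step between them, an 8.4-fold higher number from compound 1 to compound 2 (0.93 log units; beyond the scatter), leaves compound 2 with the highest of the two numbers, that is the weaker inhibition.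

The next compound, compound 3 `O=C([C@@H]1CCCN(S(=O)(=O)c2ccc(S(=O)(=O)C3CC3)cc2)C1)N1CCC(F)(F)CC1`, differs from compound 2 in one place: cyclopropyl in place of 3-hydroxypyrrolidin-1-yl on a sulfonyl sulfur. Going by the values given here, the only measured step that bears on this change is an 8.4-fold higher number from compound 1 to compound 2 (0.93 log units; beyond the scatter), which alters the same aromatic position but not the same group, so it is only a rough guide. It shows that this position tolerates sizeable changes and that a neutral group without a hydroxyl gave the lower number there, which argues against compound 3 being weaker than compound 2.

Compound 3 is therefore expected to give about 250 nM in this assay, with a likely range from 80 nM to 800 nM, which means an estimated step of a 2.4-fold lower number from compound 2 to compound 3 (0.37 log units; beyond the scatter).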

Compound 3, half-maximal inhibitory concentration: 26 nM
Beside the measured number, compound 3's estimate is 9.6-fold (0.98 log units) above it; the whole stated range lies above it.
By their numbers in this assay, from the lowest: compound 3; then compound 1; then compound 2.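

In this assay the step of a 23-fold lower number from compound 2 to compound 3 (1.36 log units; beyond the scatter) shows that the group on this sulfonyl sulfur can move the number a great deal by itself, with the rest of the molecule unchanged. The earlier pair could not show this, since the step from compound 1 to compound 2 replaced the whole diethylcarbamoyl group, so a change of the sulfonyl link and a change of the group on it could not be told apart. The further step of a 2.7-fold lower number from compound 1 to compound 3 (0.43 log units; beyond the scatter) shows that a sulfonyl group on this aromatic carbon does not in itself go with a weaker result, as compound 3 carries one and is the strongest of the three, yet nothing available here says why the number falls with this change.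

The change removes a hydroxyl, a ring nitrogen and a larger ring all at once, so the compounds shown leave open which of these goes with the large step. Plain pyrrolidin-1-yl, which lacks only the hydroxyl, would help to separate them, as would a methyl or cyclobutyl group on the same sulfonyl sulfur.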